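Removing a methylene between piperazine and pyridine

The source may hold more compounds than are shown below. What is called first, only, known or untested is meant among the compounds shown, and "the series" means these compounds.

Compound 1 `Nc1ccccc1NC(=O)c1ccc(CSC(=S)N2CCN(c3ccc(Cl)cc3)CC2)cc1`: 32.2%
Compound 2 `Nc1ccccc1NC(=O)c1ccc(CSC(=S)N2CCN(Cc3ccncc3)CC2)cc1`: 33.1%

Both compounds were tested in a functional assay on A-375 cells (Homo sapiens) for antiproliferative activity, read by CCK-8 assay, with a stated time of 72 h, tested at 2 uM; a higher number here means a stronger effect of the compound at the concentration tested, a lower number a weaker effect. Compound 2 gives 33.1%, the higher of the two numbers, but its nearest neighbour, compound 1 with 32.2%, lies within the scatter, so the two cannot be ordered. Within the data shown here, the one measured step, a number 0.9 percentage points higher from compound 1 to compound 2 (within the scatter), changes the group on the amine nitrogen in the ring and does nothing beyond the scatter.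

Compound 3 `Nc1ccccc1NC(=O)c1ccc(CSC(=S)N2CCN(c3ccncc3)CC2)cc1` differs from compound 2 at the same position: pyridin-4-yl in place of (pyridin-4-yl)methyl on an amine nitrogen in a ring. The measured step bears on it only loosely, since it exchanged one whole group for another at that nitrogen without effect. Compound 3 is therefore expected to show a step of a number 1.1 percentage points lower from compound 2 to compound 3 (within the scatter), that is, none beyond the scatter. The value of compound 3 in this assay is estimated at 32%, within 18% to 46%.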

Compound 3, a percentage reported as inhibition, at one concentration (the size of the read-out at that concentration, not a potency): 85.7%
Beside the measured number, compound 3's estimate is 53.7 percentage points below it, outside the stated range (above it).
By their numbers in this assay, from the lowest: compounds 1 and 2 (each within the scatter of the next); then compound 3.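

In this assay, pyridin-4-yl in place of (pyridin-4-yl)methyl gives a number 52.6 percentage points higher from compound 2 to compound 3 (beyond the scatter), so this position on an amine nitrogen in a ring is far from indifferent, although the earlier exchange there gave only a number 0.9 percentage points higher from compound 1 to compound 2 (within the scatter). Pyridin-4-yl in place of 4-chlorophenyl gives a number 53.5 percentage points higher from compound 1 to compound 3 (beyond the scatter), so among these compounds neither a six-membered aromatic ring on that nitrogen nor a pyridine ring linked through a methylene is enough, and only the pyridine ring without the methylene gives the high number. No evidence is at hand on why this single change matters so much.

The compounds shown leave open whether the ring nitrogen must sit as in pyridin-4-yl, as pyridin-3-yl or plain phenyl would show. They also leave open how a two-carbon ethylene chain to the pyridine ring would behave.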